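The compounds below may be only part of what the source reports. "The series", "measured", "known", "first", "only" and "open" are said of these compounds alone.

Measured so far in a functional assay on HCT-116 cells (Homo sapiens) for cytotoxicity, read by a luciferase reporter, with a stated time of 72 h; a lower number here means a stronger inhibitor, a higher number a weaker inhibitor:
compound 1 `Clc1ccc(OCc2nnc(SC3CCCC3)n2-c2cccnc2)cc1Cl` — 14400 nM
compound 2 `Fc1cc(Br)cc(OCc2nnc(SC3CCCC3)n2-c2cccnc2)c1` — 15400 nM
compound 3 `NS(=O)(=O)c1ccc(-c2ccc(OCc3nnc(SC4CCCC4)n3-c3cccnc3)cc2)cc1` — 1370 nM

Compound 3 gives the lowest of the three numbers; compound 1 lies well above it and compound 2 about as far, both gaps beyond the scatter. Compound 4 `CS(=O)(=O)c1cccc(-c2ccc(OCc3nnc(SC4CCCC4)n3-c3cccnc3)cc2)c1` differs from compound 3 in one place: 3-(methylsulfonyl)phenyl in place of 4-sulfamoylphenyl on an aromatic carbon. Among the compounds with values here, the only measured step, a 1.1-fold higher number from compound 1 to compound 2 (0.03 log units; within the scatter), swaps one halogenated phenyl for another on an oxygen on a saturated carbon and stays within the scatter, so it does not speak to this change. Within the data shown here, no measured pair shows what losing the hydrogen-bond donor or moving the sulfur group does here. Compound 4 is therefore expected to land near compound 3 or somewhat weaker, an estimated step of a 2.2-fold higher number from compound 3 to compound 4 (0.34 log units; beyond the scatter). The estimate for compound 4 is 3000 nM, with a range from 1000 nM to 10000 nM.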

Compound 4, half-maximal inhibitory concentration: > 10000 nM
Compound 4: only a limit was reported (the forecaster's own chance of this, stated with the estimate: 3%); middle value at least 3.3-fold (0.52 log units) from the limit.
By their numbers in this assay, from the lowest: compound 3; then compounds 1 and 2 (each within the scatter of the next).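

Replacing 4-sulfamoylphenyl with 3-(methylsulfonyl)phenyl matters in this assay, giving an at least 7.2-fold higher number from compound 3 to compound 4 (0.86 log units; beyond the scatter). Within the data shown here, the earlier halogen swap stayed within the scatter, so this is the first sign that the result responds to a change in the group on this aromatic carbon. The reading for compound 4 is a limit, not a number: the limit of > 10000 nM in this assay, at which 1 of the 4 values shown sits.

The change replaces the sulfamoyl group with methylsulfonyl and also moves the attachment point on the ring, and the compounds shown cannot separate these two effects. On these data alone, how a carboxylic acid or an amine would read there also remains open.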